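Fluoro replaces hydrogen on a shared uracil-type core

A few compounds are considered here, and "the series" means these few. Any claim that something is new, unique, unknown or untested is made for them only; others in the source may bear on it.

Compound 1 `CC(=O)O[C@@H]1[C@@H](F)[C@@H](CSC(C)=O)O[C@H]1n1cc(C)c(=O)[nH]c1=O` gives 278000 nM in a functional assay on cells (Melanoma cell, Homo sapiens) for cytotoxicity, with a stated time of 72 h; a lower number here means that less compound is tolerated, a higher number that more compound is tolerated.
Compound 2 `CC(=O)O[C@@H]1[C@@H](F)[C@@H](CSC(C)=O)O[C@H]1n1ccc(=O)[nH]c1=O` gives 17300 nM in this assay.

For the measured compounds named here, of the two numbers measured so far, compound 2 has the lower one; its nearest neighbour is compound 1, and the step between them, a 16-fold lower number from compound 1 to compound 2 (1.21 log units; beyond the scatter), is large. Compound 3 `CC(=O)O[C@@H]1[C@@H](F)[C@@H](CSC(C)=O)O[C@H]1n1cc(F)c(=O)[nH]c1=O` is not yet measured. It differs from compound 2 in one place: fluoro in place of hydrogen on an aromatic carbon. Going by the values given here, the only measured step, from compound 1 to compound 2, concerns the removal of a methyl from the same aromatic carbon, so it shows that this position matters for the numbers in this assay, but it says nothing about what a fluoro group there will do. Among the compounds with values here, no measured pair shows a hydrogen-to-fluoro exchange. The expectation therefore rests on little: a change at a position already shown to move the numbers, in an unknown direction. Compound 3 is estimated to land near compound 2, with a wide range allowing movement either way, the expected step being a 2.9-fold lower number from compound 2 to compound 3 (0.46 log units; beyond the scatter). For compound 3 the estimate in this assay is 6000 nM, with a range from 500 nM to 40000 nM.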

Compound 3, half-maximal cytotoxic concentration: 16500 nM
Estimate against measurement, compound 3: 2.8-fold (0.44 log units) below; the measured number falls inside the stated range.
By their numbers in this assay, from the lowest: compounds 3 and 2 (each within the scatter of the next); then compound 1.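

In this assay, fluoro in place of hydrogen on this aromatic carbon gives a 1.0-fold lower number from compound 2 to compound 3 (0.02 log units; within the scatter), so this exchange leaves compound 2 and compound 3 indistinguishable here, which the earlier pair could not show. The methyl of compound 1 now stands apart from both other groups: fluoro in its place gives a 17-fold lower number from compound 1 to compound 3 (1.23 log units; beyond the scatter), a step of about the same size as a 16-fold lower number from compound 1 to compound 2 (1.21 log units; beyond the scatter), seen with hydrogen in its place, so among these three compounds only the methyl goes with the much higher number, meaning that far more compound is tolerated. Nothing available explains why the methyl compound differs from the other two or why hydrogen and fluoro match.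

From the compounds shown here alone, what stays open is whether this separation belongs to methyl alone or extends to other carbon groups on the same aromatic carbon, such as ethyl, trifluoromethyl or a longer chain. Going by these compounds, it is also open whether chloro, an amine or a carboxylic acid there would stay with hydrogen and fluoro, stay with methyl, or fall elsewhere in this assay.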